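From hydroxy to amino on the side chain

The source may hold more compounds than are shown below. What is called first, only, known or untested is meant among the compounds shown, and "the series" means these compounds.

Going by the values given here, in a functional assay on HeLa cells (Homo sapiens) for antiproliferative activity, read by MTT assay, with a stated time of 48 h (a lower number here means a stronger inhibitor, a higher number a weaker inhibitor), compound 2 (`C=C(c1ccc(OC)cc1NC(=O)CO)c1ccc(OC)c2c1OC(C)(C)C=C2`) gives 40 nM and holds the lower of the two numbers so far. In this assay compound 1 (`CNCC(=O)Nc1cc(OC)ccc1C(=O)c1ccc(OC)c2c1OC(C)(C)C=C2`) gives 870 nM and so stands above it, by a gap well beyond the usual scatter. Compound 3 (`C=C(c1ccc(OC)cc1NC(=O)CN)c1ccc(OC)c2c1OC(C)(C)C=C2`) is compound 2 with amino in place of hydroxy on a saturated chain carbon bound to a carbonyl carbon. Among the compounds with values here, no measured pair of compounds shows this change alone, so there is no direct guide to its size. The expectation starts from compound 2 at 40 nM and allows a modest move toward a higher number in this assay that stays close to the scatter. The expected change is a 1.5-fold higher number from compound 2 to compound 3 (0.18 log units; within the scatter) as a rough estimate. For compound 3 the estimated value is 60 nM with an expected range of 15 nM to 250 nM for repeated measurements.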

Compound 3, half-maximal inhibitory concentration: 120 nM
The estimate for compound 3 lay 2.0-fold (0.30 log units) below the measured number; low and high end bracket the measured number.
By their numbers in this assay, from the lowest: compound 2; then compound 3; then compound 1.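

Going by these compounds alone, the change of hydroxy to amino on a saturated chain carbon bound to a carbonyl carbon gives a 3.0-fold higher number from compound 2 to compound 3 (0.48 log units; beyond the scatter) in this assay and provides the first single-place comparison in this set. The position therefore responds to the exchange of one heavy atom, even though the two groups carry the same printed counts of hydrogen-bond donors and acceptors and neither has a net charge. The data offer no information on what lies behind this step.

The compounds shown leave open how a dimethylamino group, a carboxylic acid or a longer chain would fare at this place. Also open, from the compounds shown here alone, is what a methylamino group would give on the core of compound 3, which would connect that compound to compound 1 one place at a time.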